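Hydroxyurea Variation on a Tetrahydrofuran Scaffold for PAF Binding

The compounds below may be only part of what the source reports. "The series", "measured", "known", "first", "only" and "open" are said of these compounds alone.

Within the data shown here, compound 1 `CCCNC(=O)N(O)c1cc([C@H]2CC[C@H](c3cc(OC)c(OC)c(OC)c3)O2)cc(OCCC)c1OCCC` is the only compound here with a single number in an assay for binding affinity to platelet-activating factor receptor (Homo sapiens); on this read-out lower numbers stand for stronger inhibition and higher numbers for weaker inhibition: compound 1 gives 91 nM. Compound 2 `CCCOc1c(NC(=O)N(O)C(C)(C)C)cc(C2CCC(c3cc(OC)c(OC)c(OC)c3)O2)cc1OC` was tested more than once, and in this assay compound 2 gives 26 nM; 456 nM (2 entries), a spread shown by the several entries of compound 2 in this assay, 26 nM; 456 nM (2 entries). Compound 3 `CCCOc1cc([C@H]2CC[C@H](c3cc(OC)c(OC)c(OC)c3)O2)cc(N(CC)C(=O)N(O)CC)c1OCCC` differs from compound 1 by ethyl(ethyl(hydroxy)carbamoyl)amino in place of hydroxy(propylcarbamoyl)amino on an aromatic carbon. Among the measured compounds shown here, with no measured step of this kind to lean on, the shift from compound 1 to compound 3 is expected to be a modest loss, a 2.2-fold higher number from compound 1 to compound 3 (0.34 log units; beyond the scatter), not far beyond the scatter. Compound 3 is therefore estimated at 200 nM, within 50 nM to 800 nM.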

Compound 3, half-maximal inhibitory concentration: 17 nM
For compound 3 the middle estimate is 12-fold (1.07 log units) above the measured one; measured number outside the range, below it.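

Placing ethyl(ethyl(hydroxy)carbamoyl)amino in place of hydroxy(propylcarbamoyl)amino on this aromatic carbon, ortho to a propoxy group, gives a 5.4-fold lower number from compound 1 to compound 3 (0.73 log units; beyond the scatter) in this assay. So this position accepts the larger group, which carries one hydrogen-bond donor where the group it replaces carries two, without any loss on this read-out. The size of the step calls for caution, since repeated entries for a single compound can lie far apart: the several entries of compound 2 in this assay, 26 nM; 456 nM (2 entries)

Among these compounds, the single change alters both nitrogens together, so which ethyl group goes with the lower number stays open. On these data alone, how a butyl chain or an amine would read at this position also remains open.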